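Removing the Last Methyl from a Sulfamoylamino Group

A few compounds are considered here, and "the series" means these few. Any claim that something is new, unique, unknown or untested is made for them only; others in the source may bear on it.

Three measured compounds share one core and differ only at the sulfonamide nitrogens. Compound 3 `CCN1CCCC1CNC(=O)c1cc(NS(=O)(=O)NC)ccc1OC` gives in a functional assay on the whole organism for inhibition, with Mus musculus as the target (a lower number here means that less compound is needed, a higher number that more compound is needed for the effect), only the assay's limit of > 50 mg/kg. Compound 1 `CCN1CCCC1CNC(=O)c1cc(NS(=O)(=O)N(C)C)ccc1OC` likewise reaches only the limit > 50 mg/kg in this assay. Compound 2 `CCN1CCCC1CNC(=O)c1cc(N(C)S(=O)(=O)N(C)C)ccc1OC` gives 36.2 mg/kg in this assay. Compound 4 `CCN1CCCC1CNC(=O)c1cc(NS(N)(=O)=O)ccc1OC` is not yet measured; it differs from compound 3 by hydrogen in place of methyl on a sulfonamide nitrogen. Among the measured compounds shown here, the steps that bear on this change are an at least 1.3-fold lower number from compound 1 to compound 2 (0.14 log units; that floor lies within the scatter) and a step that the two limits leave unreadable from compound 1 to compound 3, with an at least 1.3-fold higher number from compound 2 to compound 3 (0.14 log units; that floor lies within the scatter) alongside; two of these values sit at the limit of > 50 mg/kg in this assay, at which 2 of the 3 values shown sit. Because an at least 1.3-fold lower number from compound 1 to compound 2 (0.14 log units; that floor lies within the scatter) ran toward a lower dose, the reverse change in compound 4 is expected to read as a step that the limit leaves unreadable from compound 3 to compound 4. Compound 4 is therefore expected near 65 mg/kg, between 30 mg/kg and 150 mg/kg, most likely again as a limit.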

Compound 4, dose for half-maximal effect: > 50 mg/kg
Compound 4 ended at the assay's limit (the forecaster's own chance of this, stated with the estimate: 75%); the middle value does not contradict the limit.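

Taking the last methyl off this sulfonamide nitrogen, methylsulfamoyl to sulfamoyl, yields no readable change, and neither of the steps between two limits can be read, because compound 1, compound 3 and compound 4 all stop at a limit of the assay: the limit of > 50 mg/kg in this assay, at which 3 of the 4 values shown sit.

Among the compounds shown here, the only readable new step is an at least 1.3-fold higher number from compound 2 to compound 4 (0.14 log units; that floor lies within the scatter), so even the fully demethylated group shows no firm separation from compound 2.

From the compounds shown here alone, how far compound 3 and compound 4 actually lie apart stays open. So does whether an ethyl group or a longer chain on this sulfonamide nitrogen would give a measurable dose in this assay.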